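The source may report more compounds than this note shows. Statements on the series, on what has been measured and on what is new or still open speak of the compounds shown alone.

Three amides built on one shared core have been tested in a functional assay on B16 cells (Mus musculus) for inhibition; on this read-out higher numbers stand for weaker inhibition and lower numbers for stronger inhibition. In this assay, compound 1 (`O=C(/C=C/c1ccc(O)c(O)c1)NC1CCCCC1`) gives 2800 nM, compound 2 (`O=C(/C=C/c1ccc(O)c(O)c1)Nc1cccc([N+](=O)[O-])c1`) gives 1900 nM, and compound 3 (`Cc1ccc(CNC(=O)/C=C/c2ccc(O)c(O)c2)cc1`) gives 3700 nM. Compound 3 therefore stands level with the other two, since all three numbers lie within the usual scatter of repeat measurements. Compound 4 (`O=C(/C=C/c1ccc(O)c(O)c1)NCc1ccc(Cl)cc1`) differs from compound 3 by one swap: chloro in place of methyl on an aromatic carbon. Among the measured compounds shown here, no measured pair shows this swap directly, but the three compounds stay within the scatter despite their differing groups, so no clear direction is expected. The expected 1.2-fold lower number from compound 3 to compound 4 (0.06 log units; within the scatter) stays within the scatter. For compound 4 the estimated value is 3200 nM, with an expected range of 1600 nM to 6400 nM.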

Compound 4, half-maximal inhibitory concentration: 1800 nM
For compound 4 the middle estimate is 1.8-fold (0.25 log units) above the measured one; measured number inside the range.
By their numbers in this assay, from the lowest: compounds 4, 2, 1 and 3 (each within the scatter of the next, the first and the last beyond it).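

In this assay the change from 4-methylphenyl to 4-chlorophenyl brings a 2.1-fold lower number from compound 3 to compound 4 (0.31 log units; beyond the scatter) and gives the series its first step in one place. Among the compounds shown here, a swap of one heavy atom on the aromatic ring, para to a large group, thus moves the number modestly, something the earlier compounds, which differ in more than one place, could not show. No measurement here accounts for this step. As far as these compounds go, how this position responds to other groups, such as fluoro, methoxy or an amine, remains open.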